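The compounds below may be only part of what the source reports. "The series", "measured", "known", "first", "only" and "open" are said of these compounds alone.

Compound 3, `N#Cc1c(Nc2ccc(Cl)cc2)nc(SCC(=O)Nn2c(COc3ccc(Cl)cc3Cl)nc3ccccc3c2=O)nc1-c1ccc(Cl)cc1`, stands second highest of the three measured compounds: in a functional assay on the whole organism (strain albino) for inhibition, with Rattus norvegicus as the target, read by paw edema, with a stated time of 1 h, at a dose of 100 mg/kg by the oral route (a higher number here means more inhibition at the dose given (going by the name of the read-out), a lower number less inhibition), compound 3 gives 54.6%. Compound 1, `N#Cc1c(Cl)nc(SCC(=O)Nn2c(COc3ccc(Cl)cc3Cl)nc3ccccc3c2=O)nc1-c1ccc(Cl)cc1`, gives 63.6% in this assay, and compound 2, `N#Cc1c(Nc2ccccc2)nc(SCC(=O)Nn2c(COc3ccc(Cl)cc3Cl)nc3ccccc3c2=O)nc1-c1ccc(Cl)cc1`, gives 43.6%. Compound 4, `N#Cc1c(Nc2ccc(O)cc2)nc(SCC(=O)Nn2c(COc3ccc(Cl)cc3Cl)nc3ccccc3c2=O)nc1-c1ccc(Cl)cc1`, is the compound not yet measured. The change from compound 3 to compound 4 is hydroxy in place of chloro on an aromatic carbon, on an aromatic carbon of a six-membered aromatic ring of carbon only, para to a large group. Among the measured compounds shown here, two measured steps bear on it: a number 9 percentage points lower from compound 1 to compound 3 (within the scatter) and a number 11 percentage points higher from compound 2 to compound 3 (beyond the scatter), the latter being the step in which the same chloro enters on that ring. For the measured compounds named here, removing the chloro again and putting in a hydroxy has no direct precedent here; the steps so far suggest that a change at this place moves the read-out modestly, if at all. Compound 4 is therefore expected to give roughly 50% in this assay, in the range 38% to 62%, a step of a number 4.6 percentage points lower from compound 3 to compound 4 (within the scatter) that is expected to lie within the scatter.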

Compound 4, a percentage reported as inhibition, in the whole organism at one dose (the size of the read-out at that dose, not a potency): 90.9%
Compound 4: the middle estimate sits 40.9 percentage points below what was measured; the whole stated range lies below it.
By their numbers in this assay, from the lowest: compound 2; then compounds 3 and 1 (each within the scatter of the next); then compound 4.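

In this assay, among the compounds shown here, the ring carbon para to a large group proves far more responsive than the earlier compounds showed: hydroxy in place of chloro gives a number 36.3 percentage points higher from compound 3 to compound 4 (beyond the scatter) and hydroxy in place of hydrogen gives a number 47.3 percentage points higher from compound 2 to compound 4 (beyond the scatter), so the outcome depends strongly on which group sits there. The (4-hydroxyphenyl)amino group also clearly surpasses the chloro of compound 1, with a number 27.3 percentage points higher from compound 1 to compound 4 (beyond the scatter), which neither anilino nor (4-chlorophenyl)amino did. Nothing available explains why hydroxy has this effect.

On these data alone, whether a methoxy, an amine or a carboxylic acid at this place would match hydroxy remains open. So does whether the gain holds at other oral doses and times, since a single dose and time give no potency.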